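Swapping Benzyl for Benzimidazole on the Sulfur Chain

This account rests on a few compounds, and the source may have more. Where it says the series, first, only, none or still open, it means among the compounds named here.

Compound 1 `Cc1cc(Nc2cc(-c3ccccc3)[nH]n2)n2nc(SCCc3ccccc3)nc2n1` was tested in a functional assay on MCF7 cells (Homo sapiens) for inhibition, read by MTT assay, with a stated time of 72 h (on this read-out higher numbers stand for weaker inhibition and lower numbers for stronger inhibition), where compound 1 gives 2700 nM. Among the two numbers known so far, that is the lowest; compound 3 `Cc1cc(Nc2cc(-c3ccccc3)[nH]n2)n2nc(SCCCc3ccccc3)nc2n1` gives 3900 nM, and the step of a 1.4-fold higher number from compound 1 to compound 3 (0.16 log units; within the scatter) therefore stays within the scatter. Compound 2 `Cc1cc(Nc2cc(-c3ccccc3)[nH]n2)n2nc(SCC3CCCCC3)nc2n1` gives no number at all: its result is a limit of the assay, > 50000 nM. Against that limit, the steps of an at least 18-fold higher number from compound 1 to compound 2 (1.26 log units; beyond the scatter) and an at least 12-fold lower number from compound 2 to compound 3 (1.10 log units; beyond the scatter) are both large, resting on (the limit of > 50000 nM in this assay, at which 1 of the 3 values shown sits).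

Compound 4 `Cc1cc(Nc2cc(-c3ccccc3)[nH]n2)n2nc(SCc3nc4ccccc4[nH]3)nc2n1` is the compound still to be measured. From compound 1 it differs in one place: 1H-benzimidazol-2-yl in place of benzyl on a saturated chain carbon bound to a sulfur. Among the measured compounds shown here, the steps that bear on this change are the two that involve compound 2, where trading the aromatic ring on the sulfur chain for cyclohexyl goes with a large rise in the number, and the step of a 1.4-fold higher number from compound 1 to compound 3 (0.16 log units; within the scatter), which shows that adding one carbon to that chain changes little. Compound 4 keeps an aromatic ring system on the chain, though a shorter one carrying a hydrogen-bond donor and acceptor, so the expected step of a 1.1-fold higher number from compound 1 to compound 4 (0.05 log units; within the scatter) is small, with no clear direction. Compound 4 is therefore estimated at 3000 nM, expected to fall between 800 nM and 12000 nM.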

Compound 4, half-maximal inhibitory concentration: 2730 nM
Beside the measured number, compound 4's estimate is 1.1-fold (0.04 log units) above it; low and high end bracket the measured number.
By their numbers in this assay, from the lowest: compounds 1, 4 and 3 (each within the scatter of the next). At a limit, above all of these: compound 2.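

In this assay, putting 1H-benzimidazol-2-yl in place of benzyl on the saturated chain carbon bound to the sulfur gives a 1.0-fold higher number from compound 1 to compound 4 (0.00 log units; within the scatter), and the comparison with the longer phenethyl-ended chain gives a 1.4-fold lower number from compound 3 to compound 4 (0.15 log units; within the scatter). Among the compounds shown here, the earlier compounds carried only aromatic rings of carbon on this chain, so this is the first sign that the position can take a ring with nitrogen atoms, plus a hydrogen-bond donor and acceptor, without a step beyond the scatter. The large step of an at least 18-fold lower number from compound 2 to compound 4 (1.26 log units; beyond the scatter) leaves the cyclohexyl compound, the only one here without an aromatic ring on the chain, apart from the other three, though that compound's result is a limit of the assay and not a number: the limit of > 50000 nM in this assay, at which 1 of the 4 values shown sits.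

From the compounds shown here alone, it remains open whether the hydrogen on the benzimidazole nitrogen plays any part in this result, which a benzimidazole carrying a methyl group on that nitrogen could test. A pyridin-2-ylmethyl group, or a phenethyl group whose ring carries a carboxylic acid or an amine, would show how much further this position can be changed.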